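The compounds below may be only part of what the source reports. "The series", "measured", "known", "first", "only" and "open" are said of these compounds alone.

Measured so far in a functional assay on HCT-15 cells (Homo sapiens) for inhibition, read by sulforhodamine B assay, with a stated time of 48 h; a lower number here means a stronger inhibitor of growth, a higher number a weaker inhibitor of growth:
- compound 1 `O=C(Nc1cccc(-n2cc(-c3ccncc3)c(-c3ccc(Cl)c(O)c3)n2)c1)Nc1cc(C(F)(F)F)cc(C(F)(F)F)c1`: 3520 nM
- compound 2 `COc1cc(-c2nn(-c3cccc(NC(=O)Nc4ccc(Cl)c(C(F)(F)F)c4)c3)cc2-c2ccncc2)ccc1Cl`: 7050 nM
- compound 3 `COc1cc(-c2nn(-c3cccc(NC(=O)c4ccccc4)c3)cc2-c2ccncc2)ccc1Cl`: a limit of this assay, > 100000 nM

Among the compounds with values here, compound 1 holds one of only two numbers, and the gap to compound 2 is within the scatter. Within the data shown here, the one measured step, an at least 14-fold higher number from compound 2 to compound 3 (1.15 log units; beyond the scatter), is large; compound 3 sits at the limit of > 100000 nM in this assay, at which 1 of the 3 values shown sits, so its true size is not known.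

Compound 4 `COc1cc(-c2nn(-c3cccc(NC(=O)Nc4cc(C(F)(F)F)cc(C(F)(F)F)c4)c3)cc2-c2ccncc2)ccc1Cl` differs from compound 1 by methyl in place of hydrogen on an oxygen on an aromatic ring. Among the measured compounds shown here, no measured step isolates this change: compound 2 carries the methoxy but differs from compound 1 in a second place too, so nothing here ties the methyl on the oxygen to a step of its own. Compound 4 is therefore expected close to compound 1, with a 1.4-fold higher number from compound 1 to compound 4 (0.15 log units; within the scatter) within the scatter, at an estimated 5000 nM (range 1800 nM to 14000 nM).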

Compound 4, concentration for total growth inhibition: 1640 nM
Beside the measured number, compound 4's estimate is 3.0-fold (0.48 log units) above it; the measured number lies below the stated range.
By their numbers in this assay, from the lowest: compound 4; then compounds 1 and 2 (each within the scatter of the next). At a limit, above all of these: compound 3.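

Hydroxy to methoxy on the 4-chloro-3-hydroxyphenyl group gives, in this assay, a 2.1-fold lower number from compound 1 to compound 4 (0.33 log units; beyond the scatter) and so isolates this oxygen for the first time. At this position a methyl is tolerated, and the free hydroxy is not required for growth inhibition in this series. Nothing measured here gives a cause for this step.

On these data alone, whether an ethoxy or an amine at this position would move the number further remains open. Also open, as far as these compounds go, is whether the same step holds with the 4-chloro-3-(trifluoromethyl)phenyl group of compound 2.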